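A few compounds are considered here, and "the series" means these few. Any claim that something is new, unique, unknown or untested is made for them only; others in the source may bear on it.

Going by the values given here, compound 1 `COc1cc(-c2ncnn2-c2cccc(F)c2)cc(OC)c1OC` and compound 2 `CCOc1ccc(-c2ncnn2-c2cc(OC)c(OC)c(OC)c2)cc1Cl` are the two measured members of this set. In a functional assay on A549 cells (Homo sapiens) for antiproliferative activity, read by MTT assay, with a stated time of 72 h (a higher number here means a weaker inhibitor, a lower number a stronger inhibitor), compound 2 gives 10 nM. In this assay compound 1 gives only a limit, > 10000 nM, and no number. Compound 1 thus stands at the limit of > 10000 nM in this assay, at which 1 of the 2 values shown sits, with no value of its own to place it more exactly. Compound 3 `COc1cc(-c2ncnn2-c2ccc(Cl)c(Cl)c2)cc(OC)c1OC` differs from compound 1 by 3,4-dichlorophenyl in place of 3-fluorophenyl on an aromatic nitrogen. Among the compounds with values here, no step between measured compounds shows what such a change does here. Within the data shown here, for this assay a modest move toward stronger inhibition is expected for compound 3, though it may not clear the usual scatter; compound 2 gives 10 nM but no step connects it to compound 1 or to compound 3. Compound 3 is therefore estimated at 6000 nM, within a range from 1500 nM to 30000 nM. This amounts to an expected step of an at least 1.6-fold lower number from compound 1 to compound 3 (0.22 log units; that floor lies within the scatter).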

Compound 3, half-maximal inhibitory concentration: > 10000 nM
Compound 3 ended at the assay's limit; the forecaster's own chance of this, stated with the estimate: 45%; middle value at least 1.6-fold (0.22 log units) from the limit.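

Compound 1 and compound 3 both end at a limit rather than a number in this assay, so no step between them can be read: the limit of > 10000 nM in this assay, at which 2 of the 3 values shown sit.

The compounds shown leave open whether 3,4-dichlorophenyl in place of 3-fluorophenyl on an aromatic nitrogen changes antiproliferative activity at all.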